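From naphthalen-1-yl to thiophen-2-yl at low growth inhibition

The source may report more compounds than this note shows. Statements on the series, on what has been measured and on what is new or still open speak of the compounds shown alone.

Results in a functional assay on PC-3 cells (Homo sapiens) for inhibition, read by sulforhodamine B assay, with a stated time of 48 h, tested at 50 uM; on this read-out lower numbers stand for less inhibition of growth and higher numbers for more inhibition of growth at the one concentration tested:
compound 1 `COc1cc(/C=C/C(=O)/C=C/c2cccc3ccccc23)ccc1OCc1cn(CCCOc2cc(=O)oc3ccccc23)nn1` gives 8%
compound 2 `COc1ccccc1/C=C/C(=O)/C=C/c1ccc(OCc2cn(CCCCOc3cc(=O)oc4ccccc34)nn2)c(OC)c1` gives "not active" (no number reported)
compound 3 `COc1cc(/C=C/C(=O)/C=C/c2cccs2)ccc1OCc1cn(CCCCOc2cc(=O)oc3ccccc23)nn1` gives "not active" (no number reported)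

For the measured compounds named here, compound 1 holds the only number in this small set, while compound 2 and compound 3 were reported without one, so it cannot be ranked on numbers against either. Compound 4 `COc1cc(/C=C/C(=O)/C=C/c2cccs2)ccc1OCc1cn(CCCOc2cc(=O)oc3ccccc23)nn1` has yet to be measured. Compared with compound 1, it carries thiophen-2-yl in place of naphthalen-1-yl on a double-bonded chain carbon bound to a double-bonded chain carbon and is otherwise the same.

Going by the values given here, no measured pair of compounds differs in one place only, so the data do not size this change directly. The expectation rests on compound 1 at 8% and on compound 3, which also carries thiophen-2-yl and stands at "not active" (no number reported) without a number. The estimated step of a number 2 percentage points lower from compound 1 to compound 4 (within the scatter) is expected to be slight and downward, within the usual scatter of this assay results. For compound 4 the estimated value is 6% with an expected range from 0% to 18% and a real chance of no number at all.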

Compound 4, percent growth inhibition at one concentration: "not active" (no number reported)
No number was reported for compound 4; no gap can be computed for the estimate.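

In this assay, for the compounds shown here, compound 4 gives "not active" (no number reported), so no step from compound 1, at 8%, can be read. Nothing shown here bears on the cause of this result. The compounds shown leave open how far thiophen-2-yl in place of naphthalen-1-yl shifts growth inhibition.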